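The source may hold more compounds than are shown below. What is called first, only, known or untested is meant among the compounds shown, and "the series" means these compounds.

Measured so far:
compound 1 `Cn1nc(-c2ccc(Cl)cc2)n(C)c1=S`: 0.27 mg/kg
compound 2 `Cn1c(S)nnc1-c1ccccc1F`: > 200 mg/kg

Among the compounds with values here, in a functional assay on the whole organism with Mus musculus as the target (on this read-out higher numbers stand for an effect only at larger amounts of compound and lower numbers for an effect already at smaller amounts), compound 1 gives 0.27 mg/kg, the only number among the two values shown. For compound 2 the value > 200 mg/kg is a limit of the assay and not a number (the limit of > 200 mg/kg in this assay, at which 1 of the 2 values shown sits). Compound 3 `CCCn1c(-c2ccc(Cl)cc2)nn(C)c1=S` has not yet been measured; it differs from compound 1 by ethyl in place of hydrogen on a saturated chain carbon bound to an aromatic nitrogen. Within the data shown here, no measured step of this kind is available, so the expected step of a 1.9-fold higher number from compound 1 to compound 3 (0.27 log units; within the scatter) is estimated as small, within the usual scatter and in no firm direction. Compound 3 is therefore expected to give about 0.5 mg/kg in this assay, between 0.15 mg/kg and 2 mg/kg.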

Compound 3, dose for half-maximal effect: 12.5 mg/kg
Estimate against measurement, compound 3: 25-fold (1.40 log units) below, outside the stated range (above it).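

Within the data shown here, at this place, on a saturated chain carbon bound to an aromatic nitrogen, the earlier compounds offered no step, and in this assay the change of methyl to propyl now gives a 46-fold higher number from compound 1 to compound 3 (1.67 log units; beyond the scatter) and so counts for much here. Compound 3 still gives a number and not a limit of the assay, so the effect survives the longer chain at larger amounts. Nothing shown gives a cause for this step. Going by these compounds, whether the number climbs further with butyl, or already with ethyl in place of methyl, stays open. So does how an amine at the end of this chain would read.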